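A few compounds are considered here, and "the series" means these few. Any claim that something is new, unique, unknown or untested is made for them only; others in the source may bear on it.

Working notes on the series.

Of the compounds shown here, three have been measured in a physicochemical assay for lipophilicity; on this read-out higher numbers stand for higher lipophilicity and lower numbers for lower lipophilicity. Compound 1 `CC(Oc1cccc2[nH]ccc12)C1=NCCN1` gives 3.12. Compound 2 `CCOC(=O)Nc1cccc(OC(C)C2=NCCN2)c1C` gives 3.27 in this assay, and compound 3 `CCOC(=O)Nc1ccc(C)c(OC(C)C2=NCCN2)c1C` gives 4.4. Compound 1 and compound 2 are built on different cores; the difference between the two cores is not broken down here. The values of compound 1 and compound 2 lie within the scatter of each other, so nothing is read into their order.

Among the measured compounds shown here, the one change that is measured runs from compound 2 to compound 3, (methyl in place of hydrogen on an aromatic carbon), and in this assay it gave a number 1.13 log units higher from compound 2 to compound 3 (beyond the scatter).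

Compound 4 `Cc1ccc2[nH]ccc2c1OC(C)C1=NCCN1` has not yet been measured in this assay. It arises from compound 1 by the same kind of change, (methyl in place of hydrogen on an aromatic carbon). The surroundings of the place differ: in compound 4 the aromatic carbon belongs to a six-membered aromatic ring of carbon only that is part of a fused or bridged system of two rings, meta to a fused ring and para to a fused ring, whereas in compound 3 the ring is not fused and the carbon is meta to a methyl group and para to a (ethoxycarbonyl)amino group.

For the measured compounds named here, only one earlier step of this kind exists, and it was large. Given the different surroundings, a step of a number 0.58 log units higher from compound 1 to compound 4 (beyond the scatter) in this assay is expected from compound 1 to compound 4, smaller than a number 1.13 log units higher from compound 2 to compound 3 (beyond the scatter) but in the same direction. For compound 4 a value of 3.7 is estimated, with a range from 3.3 to 4.2.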

Compound 4, partition coefficient: 3.77
Compound 4: middle estimate off by 0.07 log units, on the low side; the measured number falls inside the stated range.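

In this assay methyl in place of hydrogen on an aromatic carbon gave a number 0.65 log units higher from compound 1 to compound 4 (beyond the scatter) on the core of compound 1, and on the core of compound 2 the same kind of change gave a number 1.13 log units higher from compound 2 to compound 3 (beyond the scatter) in the same direction. Among the compounds shown here, the direction therefore carried from one core to the other, but the size did not carry over unchanged, the step on the core of compound 1 being the smaller of the two; with only two steps, which also differ in the surroundings of the place, the core cannot be separated from those surroundings, and no general rule for this change follows. Nothing available bears on why the two steps differ in size.

The compounds shown leave open how a longer chain, an amine or a carboxylic acid in place of the methyl on the same aromatic carbon would read in this assay and whether any of these would follow the direction seen with methyl. They also leave open whether methyl on another aromatic carbon of the core of compound 1 would give a step of similar size, and whether a third core would follow either step.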